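This account rests on a few compounds, and the source may have more. Where it says the series, first, only, none or still open, it means among the compounds named here.

In a functional assay on PC-3 cells (Homo sapiens) for cytotoxicity, read by sulforhodamine B assay, with a stated time of 48 h (on this read-out higher numbers stand for weaker inhibition of growth and lower numbers for stronger inhibition of growth), compound 1 `ClCc1ccccc1Cn1cnc2c(Cl)nc(Cl)nc21` gives 440 nM, while compound 2 `ClCc1ccccc1Cn1cnc2c(Cl)ncnc21` gives 3020 nM. The two differ in a single place, (chloro in place of hydrogen on an aromatic carbon), and that change made a step of a 6.9-fold lower number from compound 2 to compound 1 (0.84 log units; beyond the scatter). Compound 3 `ClCc1cccc(Cn2cnc3ncnc(Cl)c32)c1` gives 2130 nM in this assay; compound 3 and compound 2 are built from the same atoms joined differently, and the difference between their two cores is not broken down here. Compound 4 `ClCc1cccc(Cn2cnc3nc(Cl)nc(Cl)c32)c1` has not yet been measured. It differs from compound 3 by chloro in place of hydrogen on an aromatic carbon, the same kind of change that turns compound 2 into compound 1. That earlier change produced the step of a 6.9-fold lower number from compound 2 to compound 1 (0.84 log units; beyond the scatter). On that basis compound 4 is expected to show a step of similar size, a 4.7-fold lower number from compound 3 to compound 4 (0.68 log units; beyond the scatter). Compound 4 is therefore estimated at 450 nM, most likely between 150 nM and 1400 nM.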

Compound 4, concentration for 50% growth inhibition: 1540 nM
The estimate for compound 4 lay 3.4-fold (0.53 log units) below the measured number, outside the stated range (above it).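

In this assay, placing a chloro on the aromatic carbon between two ring nitrogen atoms gives a 1.4-fold lower number from compound 3 to compound 4 (0.14 log units; within the scatter), so on this core the change leaves the number within the usual scatter. Set beside the earlier step, the two results clearly differ: the same change on two cores in this assay, a 6.9-fold lower number (0.84 log units; beyond the scatter) from compound 2 to compound 1 and a 1.4-fold lower number (0.14 log units; within the scatter) from compound 3 to compound 4, 5.0-fold (0.70 log units) apart, beyond the scatter of two such steps. The size of this step therefore cannot simply be carried from one core to the other in this series, but two pairs of compounds cannot show why the cores differ or how the change would behave on a third core.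

Going by these compounds, it remains open whether an amine or a methoxy group on that same carbon would give a larger step on either core. The compounds shown also leave open whether a further core would follow the larger step or the smaller one.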